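Pyridin-3-yl Amide in Place of a Difluorophenyl Amide

A few compounds are considered here, and "the series" means these few. Any claim that something is new, unique, unknown or untested is made for them only; others in the source may bear on it.

Measured compounds:
compound 1 `COc1ccc(C(=O)Nc2ccccc2C)cc1OC1CCCC1`: 300 nM
compound 2 `COc1ccc(C(=O)Nc2c(F)cccc2F)cc1OC1CCCC1`: 70 nM

Both were tested in an assay on isolated protein for inhibition of phosphodiesterase 4A (Sus scrofa); a lower number here means a stronger inhibitor, a higher number a weaker inhibitor. Compound 2 gives the lowest of the two numbers; its nearest neighbour is compound 1, and the step of a 4.3-fold lower number from compound 1 to compound 2 (0.63 log units; beyond the scatter) separates them. Compound 3 `COc1ccc(C(=O)Nc2cccnc2)cc1OC1CCCC1` is not yet measured. It differs from compound 2 in one place: pyridin-3-yl in place of 2,6-difluorophenyl on an amide-type nitrogen. Among the compounds with values here, only one measured step bears on this change, a 4.3-fold lower number from compound 1 to compound 2 (0.63 log units; beyond the scatter), and it concerns a swap between two differently substituted phenyl groups on the same nitrogen, not the exchange of a phenyl for a pyridinyl ring. Compound 1, bearing 2-methylphenyl rather than 2,6-difluorophenyl, sits at the higher number 300 nM, so an unsubstituted pyridin-3-yl is expected to give up potency as well. Compound 3 is therefore expected to show a step of a 5.7-fold higher number from compound 2 to compound 3 (0.76 log units; beyond the scatter), back toward the number of compound 1 or somewhat beyond it. The estimate for compound 3 is 400 nM, with a range from 100 nM to 1500 nM.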

Compound 3, half-maximal inhibitory concentration: 550 nM
Estimate against measurement, compound 3: 1.4-fold (0.14 log units) below; the range from low to high includes it.
By their numbers in this assay, from the lowest: compound 2; then compounds 1 and 3 (each within the scatter of the next).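

In this assay, within the data shown here, the change to pyridin-3-yl on the amide-type nitrogen gives a 7.9-fold higher number from compound 2 to compound 3 (0.90 log units; beyond the scatter) and is the first step here to replace a carbon-only ring with one holding a hetero atom; the 2,6-difluorophenyl of compound 2 is not matched by this ring. The same group set against 2-methylphenyl gives a 1.8-fold higher number from compound 1 to compound 3 (0.26 log units; within the scatter) and so does not separate compound 3 from compound 1, which leaves compound 2 alone apart from the other two. Nothing measured here accounts for these differences.

The step from compound 2 to compound 3 removes both fluorine atoms and brings in the ring nitrogen, so the compounds shown do not divide the loss between these two changes. A plain phenyl group on the same nitrogen, or a pyridin-3-yl carrying two fluorine atoms, would separate them.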